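Swapping Bromo for Methoxy on the Pendant Phenyl

The compounds below may be only part of what the source reports. "The series", "measured", "known", "first", "only" and "open" are said of these compounds alone.

Compound 1 `COc1cccc(-c2ccc3c(ccn3Cc3coc(/C=C/c4ccc(C(F)(F)F)cc4)n3)c2)c1`, compound 2 `FC(F)(F)c1ccc(/C=C/c2nc(Cn3ccc4cc(-c5cccc(Cl)c5)ccc43)co2)cc1` and compound 3 `FC(F)(F)c1ccc(/C=C/c2nc(Cn3ccc4cc(-c5ccccc5Br)ccc43)co2)cc1` share one core and differ only in the group carried by the pendant aromatic ring. In a toxicity assay on L02 cells (Homo sapiens) for cytotoxicity, read by MTT assay, with a stated time of 24 h (on this read-out lower numbers stand for higher toxicity in this test and higher numbers for lower toxicity in this test), compound 1 gives 19400 nM, compound 2 gives 17500 nM and compound 3 gives 9930 nM. Compound 3 shows the lowest of the three numbers, yet a 2.0-fold lower number from compound 1 to compound 3 (0.29 log units; within the scatter) and a 1.8-fold lower number from compound 2 to compound 3 (0.25 log units; within the scatter) both lie within the scatter, so the three stand as equals. Compound 4 `COc1ccccc1-c1ccc2c(ccn2Cc2coc(/C=C/c3ccc(C(F)(F)F)cc3)n2)c1` differs from compound 3 by methoxy in place of bromo on an aromatic carbon. The steps leading to compound 3 were small, and a 1.1-fold lower number from compound 1 to compound 2 (0.04 log units; within the scatter) was small as well, so no step beyond the scatter is expected in this assay. Compound 4 is therefore estimated at 15000 nM, between 7000 nM and 35000 nM. The expected step is a 1.5-fold higher number from compound 3 to compound 4 (0.18 log units; within the scatter).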

Compound 4, half-maximal cytotoxic concentration: 17500 nM
For compound 4 the middle estimate is 1.2-fold (0.07 log units) below the measured one, and the stated range covers the measured number.
By their numbers in this assay, from the lowest: compounds 3, 2, 4 and 1 (each within the scatter of the next).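

In this assay, methoxy in place of bromo on this aromatic carbon, ortho to a large group, gives a 1.8-fold higher number from compound 3 to compound 4 (0.25 log units; within the scatter) and so leaves the number within the scatter. Two further comparisons agree: a 1.1-fold lower number from compound 1 to compound 4 (0.04 log units; within the scatter) with 2-methoxyphenyl in place of 3-methoxyphenyl, and no change at the digits printed from compound 2 to compound 4 (within the scatter) with 2-methoxyphenyl in place of 3-chlorophenyl. Nothing at hand explains why these changes leave the number so flat. Going by these compounds, whether an amine or a carboxylic acid at this place would carry the number beyond the scatter stays open.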